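Swapping cyclohexyl for isopropyl in compound 2

The source may hold more compounds than are shown below. What is called first, only, known or untested is meant among the compounds shown, and "the series" means these compounds.

For the measured compounds named here, only two compounds have numbers so far. In a physicochemical assay for lipophilicity (a higher number here means a more lipophilic compound, a lower number a more polar compound), compound 1 (`Cc1c(C)c2c(c(C)c1O)CCC(C)(COc1ccc(/C=C3/SC(=O)NC3=O)cc1)O2`) gives 5.31 and compound 2 (`O=C1NC(=O)C(Cc2ccc(OCC3CCCCC3)cc2)S1`) gives 3.94 (the lower of the two, by a gap well beyond the usual scatter of repeat measurements).

The next compound to be measured is compound 3 (`CC(C)COc1ccc(CC2SC(=O)NC2=O)cc1`), which differs from compound 2 in one place: isopropyl in place of cyclohexyl on a saturated chain carbon bound to an oxygen on an aromatic ring. Cut one bond further out, the same change reads cyclohexylmethyl to isobutyl.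

Going by the values given here, no two measured compounds differ in just one place, so the data hold no direct precedent for this swap. The expectation rests on the structural change alone, starting from compound 2 at 3.94 and removing carbon atoms and a ring. A fall in this assay is expected, beyond the scatter, and its size is estimated as a number 1.04 log units lower from compound 2 to compound 3 (beyond the scatter) for this change. For compound 3 the estimated value is 2.9 with an expected range from 2.5 to 3.3.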

Compound 3, partition coefficient: 3.36
Compound 3: the middle estimate sits 0.46 log units below what was measured; the measured number lies above the stated range.
By their numbers in this assay, from the lowest: compound 3; then compound 2; then compound 1.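

In this assay, for the compounds shown here, putting isopropyl in place of cyclohexyl on a saturated chain carbon bound to an oxygen on an aromatic ring gives a number 0.58 log units lower from compound 2 to compound 3 (beyond the scatter), the first direct reading of what a change at this position does. Going by these compounds alone, until now, no two measured compounds differed in just one place, so the gap between them could not be tied to any single group. This swap, which goes from 6 heavy atoms to 3 and removes a six-membered non-aromatic ring of carbon only, now has a size attached to it, although that size comes from a single pair of compounds. No separate evidence is available to explain the size of this step.

This one step cannot separate the loss of the ring from the loss of carbon atoms, and an open-chain hexyl group, with the same carbon count as cyclohexyl but no ring, would pull those two apart. It also remains open how the number would move with an amine or a carboxylic acid at this position, since the groups shown here are all made of carbon only.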